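The source may report more compounds than this note shows. Statements on the series, on what has been measured and on what is new or still open speak of the compounds shown alone.

Measured compounds:
compound 1, `N#CC1=C(NC(=O)c2ccc([N+](=O)[O-])cc2)N(c2ccc(S(N)(=O)=O)cc2)C2=C(C(=O)CCC2)C1c1ccc(Cl)cc1Cl`: in a functional assay on Ehrlich cells (Mus musculus) for cytotoxicity, read by trypan blue exclusion, with a stated time of 2 h, tested at 100 ug/mL (a lower number here means a weaker effect, a higher number a stronger effect of the compound at the concentration tested), compound 1 gives 70%
compound 2, `CN(C)c1ccc(/C=N/C2=C(C#N)C(c3ccc(Cl)cc3Cl)C3=C(CCCC3=O)N2c2ccc(S(N)(=O)=O)cc2)cc1`: in this assay compound 2 gives 40%

Compound 2 stands lowest of the two numbers shown. Among the measured compounds shown here, the one step between them, a number 30 percentage points lower from compound 1 to compound 2 (beyond the scatter), was beyond the scatter, with an amide-linked nitrophenyl group giving way to an imine-linked dimethylaminophenyl group on the shared core.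

Compound 3, `CC(=O)CC(=O)NC1=C(C#N)C(c2ccc(Cl)cc2Cl)C2=C(CCCC2=O)N1c1ccc(S(N)(=O)=O)cc1`, is the unmeasured member. It differs from compound 2 as follows: a group of 7 heavy atoms (4 carbon, 1 nitrogen, 2 oxygen; no ring) in place of a group of 11 heavy atoms (9 carbon, 2 nitrogen; one six-membered aromatic ring of carbon only), on a double-bonded ring carbon. For the measured compounds named here, only the step from compound 1 to compound 2 bears on this change, and it touched the same position of the core: there, trading an amide for an imine lowered the read-out by a modest amount. Compound 3 brings an amide with one hydrogen-bond donor back to that position, though without any aromatic ring in the entering group. Going by the values given here, it is therefore expected that the number moves back upward, by a step of a number 15 percentage points higher from compound 2 to compound 3 (beyond the scatter), of the same order as the earlier loss but uncertain in size since no second example exists. Compound 3 is estimated to give 55% in this assay, within 35% to 75%.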

Compound 3, a percentage reported as activity, at one concentration (the size of the read-out at that concentration, not a potency): 80%
The estimate for compound 3 lay 25 percentage points below the measured number; the measured number lies above the stated range.
By their numbers in this assay, from the lowest: compound 2; then compounds 1 and 3 (each within the scatter of the next).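

In this assay, replacing the imine-linked dimethylaminophenyl group of compound 2 with ((2-oxopropyl)carbonyl)amino gives a number 40 percentage points higher from compound 2 to compound 3 (beyond the scatter) and so a large step, which shows that this position can carry a group with no ring and still give a strong read-out. With the amide link kept, 2-oxopropyl in place of 4-nitrophenyl on the carbonyl carbon gives a number 10 percentage points higher from compound 1 to compound 3 (within the scatter) and so no difference that can be told from scatter, which means the aromatic ring of compound 1 is not required for its read-out among these compounds. Nothing shown here accounts for why compound 2 stands apart from the two amide-linked compounds.

As far as these compounds go, the link and the aromatic group change together in compound 2, so the share of each in its lower number remains open. An imine carrying 4-nitrophenyl would separate those two parts, while an acetyl group, a carboxylic acid or a longer chain on the carbonyl carbon would show how widely the amide-linked position accepts change.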